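Changing the Ring Amine on a Shared Core

This account rests on a few compounds, and the source may have more. Where it says the series, first, only, none or still open, it means among the compounds named here.

In a functional assay on C-33-A cells (Homo sapiens) for antiproliferative activity, read by MTT assay (a higher number here means a weaker inhibitor, a lower number a stronger inhibitor), compound 1 `c1ccc2c(c1)ccn2-c1nc(N2CCNCC2)nc2ccccc12` gives 8.2 ug/mL and compound 2 `CN1CCN(c2nc(-n3ccc4ccccc43)c3ccccc3n2)CC1` gives 11.5 ug/mL. On these two numbers, compound 2 stands within the scatter of compound 1. Among the measured compounds shown here, the only measured step, a 1.4-fold higher number from compound 1 to compound 2 (0.15 log units; within the scatter), comes from methyl in place of hydrogen on an amine nitrogen in a ring. Compound 3 `c1ccc2c(c1)ccn2-c1nc(N2CCCCC2)nc2ccccc12` has piperidin-1-yl in place of 4-methylpiperazin-1-yl on an aromatic carbon, the change being (piperidin-1-yl in place of 4-methylpiperazin-1-yl on an aromatic carbon). For the measured compounds named here, the measured step touches the same group, but no measured compound carries piperidin-1-yl, so it offers only a loose guide. No step beyond the scatter is therefore expected in this assay, and no direction can be called with confidence. The expected move is a 1.2-fold lower number from compound 2 to compound 3 (0.06 log units; within the scatter). For compound 3 the estimate is 10 ug/mL, with an expected range of 4 ug/mL to 25 ug/mL.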

Compound 3, half-maximal inhibitory concentration: 50 ug/mL
Compound 3: the middle estimate sits 5.0-fold (0.70 log units) below what was measured, and the stated range ends below it.
By their numbers in this assay, from the lowest: compounds 1 and 2 (each within the scatter of the next); then compound 3.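

In this assay, the group on the aromatic carbon between two ring nitrogen atoms proves sensitive to a change in the ring itself, not just to its substituent. Methyl on the ring amine nitrogen had stayed within the scatter, yet replacing 4-methylpiperazin-1-yl with piperidin-1-yl gives a 4.3-fold higher number from compound 2 to compound 3 (0.64 log units; beyond the scatter), and replacing piperazin-1-yl with the same group gives a 6.1-fold higher number from compound 1 to compound 3 (0.79 log units; beyond the scatter), so compound 3 is the weakest of the three. The two piperazine compounds thus stay together, while the ring with one nitrogen stands apart, though the data offer no explanation for this difference.

The compounds shown leave open whether a morpholin-4-yl ring, with oxygen in place of the second nitrogen, would track compound 1 or compound 3. They also leave open how an open-chain amine such as dimethylamino would fare at this position.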